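A few compounds are considered here, and "the series" means these few. Any claim that something is new, unique, unknown or untested is made for them only; others in the source may bear on it.

In a functional assay on the whole organism for inhibition, with Mus musculus as the target (a higher number here means that more compound is needed for the effect, a lower number that less compound is needed), compound 1 `CN1Cc2c(NC(=O)CCl)cccc2C(c2ccccc2)C1` gives 10 mg/kg. Compound 2 `CN1Cc2c(NC(=O)CCCl)cccc2C(c2ccccc2)C1` gives > 30 mg/kg, which is a limit of this assay and not a number. Compound 3 `CN1Cc2c(NC(=O)OCCCl)cccc2C(c2ccccc2)C1` has yet to be measured, and its difference from compound 2 is 2-chloroethoxy in place of 2-chloroethyl on a carbonyl carbon. Within the data shown here, the only measured step that bears on this is an at least 3.0-fold higher number from compound 1 to compound 2 (0.47 log units; beyond the scatter), a different change, made on the group attached to the same carbonyl carbon. Given that step, compound 3 is expected to stay near compound 2 in this assay, with no step beyond the scatter. The expected step is a step that the limit leaves unreadable from compound 2 to compound 3. For compound 3 the estimate is 35 mg/kg, with an expected range of 12 mg/kg to 100 mg/kg.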

Compound 3, dose for half-maximal effect: 9 mg/kg
For compound 3 the middle estimate is 3.9-fold (0.59 log units) above the measured one; measured number outside the range, below it.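

In this assay, 2-chloroethoxy in place of 2-chloroethyl on this carbonyl carbon gives an at least 3.3-fold lower number from compound 2 to compound 3 (0.52 log units; beyond the scatter), so the effect is not lost with every chain that ends in chlorine at this position. 2-Chloroethoxy in place of chloromethyl gives a 1.1-fold lower number from compound 1 to compound 3 (0.05 log units; within the scatter), which leaves these two groups indistinguishable here. Compound 2 gives a limit of the assay and not a number: the limit of > 30 mg/kg in this assay, at which 1 of the 3 values shown sits.

The compounds shown leave open whether the chlorine is needed, which a plain ethoxy group on this carbonyl carbon would test. As far as these compounds go, how a longer chain such as 3-chloropropoxy would read also remains open.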